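Hydroxyl for Methoxy on the Pendant Phenyl Ring

The source may hold more compounds than are shown below. What is called first, only, known or untested is meant among the compounds shown, and "the series" means these compounds.

Three measured compounds share one core and differ only in the aromatic ring attached to it. Compound 1 `CCCS(=O)(=O)Nc1ccc(F)c(C(=O)c2n[nH]c3ncc(-c4ccccc4)cc23)c1F` carries a plain phenyl; in an assay for binding affinity to dual specificity mitogen-activated protein kinase kinase 4 (Homo sapiens), read by KINOMEscan, tested at 100 nM (a lower number here means a stronger effect, a higher number a weaker effect of the compound at the concentration tested), compound 1 gives 2.4%. Compound 2 `CCCS(=O)(=O)Nc1ccc(F)c(C(=O)c2n[nH]c3ncc(-c4ccccc4OC)cc23)c1F`, with a 2-methoxyphenyl, gives 1.9%, and compound 3 `CCCS(=O)(=O)Nc1ccc(F)c(C(=O)c2n[nH]c3ncc(-c4cccc(OC)c4)cc23)c1F`, with a 3-methoxyphenyl, gives 6.3%. Among the three numbers compound 3 stands highest, yet its distance to compound 1 and to compound 2 lies within the scatter, so no order among them can be claimed; all three leave little activity at the concentration tested.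

Compound 4 `CCCS(=O)(=O)Nc1ccc(F)c(C(=O)c2n[nH]c3ncc(-c4ccccc4O)cc23)c1F` is not yet measured. From compound 3 it differs in one place: 2-hydroxyphenyl in place of 3-methoxyphenyl on an aromatic carbon. Among the compounds with values here, compound 4 thus carries its oxygen on a 2-hydroxyphenyl, as compound 2 does on a 2-methoxyphenyl, and no other measured compound carries a hydroxyl there. All measured steps on this ring bear on the change and all were small: a number 4.4 percentage points higher from compound 2 to compound 3 (within the scatter), a number 0.5 percentage points lower from compound 1 to compound 2 (within the scatter) and a number 3.9 percentage points higher from compound 1 to compound 3 (within the scatter). Because a number 4.4 percentage points higher from compound 2 to compound 3 (within the scatter) stayed within the scatter, as did the other two steps, no step beyond the scatter is expected for the swap to a hydroxyl: a number 3.3 percentage points lower from compound 3 to compound 4 (within the scatter) is the expected change. Compound 4 is therefore estimated at 3%, within 0.5% to 12%.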

Compound 4, a percentage reported as activity, at one concentration (the size of the read-out at that concentration, not a potency): 9%
Compound 4: middle estimate off by 6 percentage points, on the low side; the range from low to high includes it.
By their numbers in this assay, from the lowest: compounds 2, 1, 3 and 4 (each within the scatter of the next).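

Compound 4 brings a hydroxyl onto the pendant phenyl ring of the shared core, and in this assay taking the methyl off the oxygen of the 2-methoxyphenyl gives a number 7.1 percentage points higher from compound 2 to compound 4 (within the scatter) while putting a hydroxy on the plain phenyl gives a number 6.6 percentage points higher from compound 1 to compound 4 (within the scatter). Swapping the 3-methoxyphenyl, which has no hydrogen-bond donor, for the 2-hydroxyphenyl, which has one, gives a number 2.7 percentage points higher from compound 3 to compound 4 (within the scatter), so at this position a hydrogen-bond donor joins the plain phenyl and both methoxyphenyl groups without any step beyond the scatter. No measurement is at hand that could explain these readings.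

Within the data shown here, what a 3-hydroxyphenyl would give stays open, and so does whether an amine or a carboxylic acid on this ring would produce the first step beyond the scatter. As far as these compounds go, all four readings come from a single concentration, so how far the compounds differ in potency also remains unknown.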